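From Nitrophenyl to Chlorophenyl: Expecting Compound 4

This account rests on a few compounds, and the source may have more. Where it says the series, first, only, none or still open, it means among the compounds named here.

Three compounds share one core and differ only in the group attached to a nitrogen on an aromatic ring. In a functional assay on MOLT-4 cells (Homo sapiens) for antiproliferative activity, read by CCK-8 assay, with a stated time of 72 h (a higher number here means a weaker inhibitor, a lower number a stronger inhibitor), compound 1 `Cc1cc(Nc2cc(N3CCN(C)CC3)nc(Nc3ccc(S(N)(=O)=O)cc3)n2)n[nH]1` gives 648 nM, compound 2 `Cc1cc(Nc2cc(N3CCN(C)CC3)nc(Nc3ccc([N+](=O)[O-])cc3)n2)n[nH]1` gives 18.1 nM, and compound 3 `Cc1cc(Nc2cc(N3CCN(C)CC3)nc(Nc3cccc([N+](=O)[O-])c3)n2)n[nH]1` gives 26 nM. Compound 2 shows the lowest of the three numbers, though its gap to compound 3, a 1.4-fold higher number from compound 2 to compound 3 (0.16 log units; within the scatter), is within the scatter, so the two cannot be separated. Compound 4 `Cc1cc(Nc2cc(N3CCN(C)CC3)nc(Nc3cccc(Cl)c3)n2)n[nH]1` carries 3-chlorophenyl in place of 4-nitrophenyl on a nitrogen on an aromatic ring. The step of a 36-fold lower number from compound 1 to compound 2 (1.55 log units; beyond the scatter) shows that the group on this phenyl ring can shift the number a great deal, while a 1.4-fold higher number from compound 2 to compound 3 (0.16 log units; within the scatter) shows that replacing 4-nitrophenyl with 3-nitrophenyl does not. Going by the values given here, no measured step compares chlorine with a nitro group, so only a modest rise is expected: a 3.3-fold higher number from compound 2 to compound 4 (0.52 log units; beyond the scatter). Compound 4 is therefore estimated at 60 nM, between 15 nM and 250 nM.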

Compound 4, half-maximal inhibitory concentration: 20.1 nM
Compound 4: the middle estimate sits 3.0-fold (0.47 log units) above what was measured; measured number inside the range.
By their numbers in this assay, from the lowest: compounds 2, 4 and 3 (each within the scatter of the next); then compound 1.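

In this assay, chloro can stand in for nitro on this phenyl ring with no change beyond the scatter (a 1.3-fold lower number from compound 3 to compound 4 (0.11 log units; within the scatter)), and the same holds for the swap of 4-nitrophenyl for 3-chlorophenyl (a 1.1-fold higher number from compound 2 to compound 4 (0.05 log units; within the scatter)), so a nitro group is not needed for a low number here. The large gap from the sulfamoyl compound remains with chlorine in place (a 32-fold lower number from compound 1 to compound 4 (1.51 log units; beyond the scatter)), leaving 4-sulfamoylphenyl alone among these four groups. Nothing measured here says why the nitro and chloro compounds read alike. Going by these compounds, whether an amine or a carboxylic acid on this phenyl ring would read like sulfamoyl or like nitro and chloro stays open.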